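The compounds below may be only part of what the source reports. "The series", "measured", "known", "first", "only" and "open" are said of these compounds alone.

Among the measured compounds shown here, in a functional assay on HL-60 cells (Homo sapiens) for inhibition, read by MTT assay, with a stated time of 48 h, tested at 10 uM (a higher number here means more inhibition of growth at the concentration tested, a lower number less inhibition of growth), compound 1 `Cc1cc(=O)c2c(O)cc(OCc3ccc(Br)cc3)c([C@H]3CCN(C)C[C@H]3O)c2o1` gives 27%, while compound 2 `Cc1cc(=O)c2c(O)cc(OCc3ccc([N+](=O)[O-])cc3)c([C@H]3CCN(C)C[C@H]3O)c2o1` gives 14%, the lower of the two numbers so far. Compound 3 `Cc1cc(=O)c2c(O)cc(OCc3ccccc3Br)c([C@H]3CCN(C)C[C@H]3O)c2o1` has not yet been measured. It differs from compound 2 by 2-bromophenyl in place of 4-nitrophenyl on a saturated chain carbon bound to an oxygen on an aromatic ring, with 2-bromophenyl in place of 4-nitrophenyl on a saturated chain carbon bound to an oxygen on an aromatic ring. For the measured compounds named here, only one measured step bears on this change: a number 13 percentage points lower from compound 1 to compound 2 (beyond the scatter), a modest step that puts nitro in place of bromo on an aromatic carbon. Going by the values given here, compound 3 loses the nitro group and carries bromo again, so that step is read in reverse, although no measured compound carries 2-bromophenyl. The expected result is a number 11 percentage points higher from compound 2 to compound 3 (beyond the scatter), a modest rise. Compound 3 is therefore estimated at 25%, with an expected range of 11% to 40%.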

Compound 3, percent growth inhibition at one concentration: 3%
The estimate for compound 3 lay 22 percentage points above the measured number, and the stated range ends above it.
By their numbers in this assay, from the lowest: compound 3; then compound 2; then compound 1.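

In this assay, exchanging 4-bromophenyl for 2-bromophenyl on a saturated chain carbon bound to an oxygen on an aromatic ring gives a number 24 percentage points lower from compound 1 to compound 3 (beyond the scatter), so at this place the outcome depends on where the bromine sits on the phenyl ring and not only on its presence. Exchanging 4-nitrophenyl for 2-bromophenyl at the same place gives a number 11 percentage points lower from compound 2 to compound 3 (beyond the scatter), so the higher number seen for bromo over nitro in the 4-substituted pair does not carry over to 2-bromophenyl. Nothing available explains why these numbers fall as they do.

As far as these compounds go, it remains open whether a plain phenyl would stand nearer to compound 1 or to compound 3. From the compounds shown here alone, it is also open whether a chloro or methoxy group in place of the bromine in 2-bromophenyl would give a number like that of compound 3.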